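The source may report more compounds than this note shows. Statements on the series, on what has been measured and on what is new or still open speak of the compounds shown alone.

Among the two compounds measured in a functional assay on HUVEC cells (Homo sapiens) for inhibition (on this read-out lower numbers stand for stronger inhibition and higher numbers for weaker inhibition), compound 2 `COc1cc(/C=C/C(=O)c2cccc(N)c2)ccc1O` stands highest, giving 2.87 ug/mL. Compound 1 `COc1cc(/C=C/C(=O)c2cccc(NC(=O)c3cccs3)c2)ccc1O` gives 0.38 ug/mL, and the step of a 7.6-fold higher number from compound 1 to compound 2 (0.88 log units; beyond the scatter) shows that taking the (thiophen-2-yl)carbonyl off that nitrogen weakened inhibition. Compound 3 `COc1cc(/C=C/C(=O)c2cccc(NC(C)=O)c2)ccc1O` puts a carbonyl group back on the same nitrogen: acetyl in place of hydrogen on a nitrogen on an aromatic ring. For the measured compounds named here, only that one step bears on this change, so a lower number than for compound 2 is expected, though acetyl is not the same group as (thiophen-2-yl)carbonyl and the step may well be smaller. For compound 3 the expected step is a 2.4-fold lower number from compound 2 to compound 3 (0.38 log units; beyond the scatter), giving an estimate of 1.2 ug/mL, between 0.5 ug/mL and 3 ug/mL.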

Compound 3, half-maximal inhibitory concentration: 7.06 ug/mL
Compound 3: the middle estimate sits 5.9-fold (0.77 log units) below what was measured; measured number outside the range, above it.
By their numbers in this assay, from the lowest: compound 1; then compound 2; then compound 3.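

In this assay, putting a carbonyl group on this nitrogen does not by itself strengthen inhibition: acetyl in place of hydrogen gives a 2.5-fold higher number from compound 2 to compound 3 (0.39 log units; beyond the scatter), the opposite direction to what the (thiophen-2-yl)carbonyl group showed. What sits on the carbonyl carbon therefore matters, with methyl in place of thiophen-2-yl giving a 19-fold higher number from compound 1 to compound 3 (1.27 log units; beyond the scatter). Nothing measured here explains this difference.

As far as these compounds go, it remains open whether the gain needs thiophen-2-yl itself or would also come with another group on that carbonyl carbon, such as phenyl, furan-2-yl or a longer alkyl chain.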